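A few compounds are considered here, and "the series" means these few. Any claim that something is new, unique, unknown or untested is made for them only; others in the source may bear on it.

Measured in a functional assay on MCF7 cells (Homo sapiens) for antiproliferative activity, read by MTT assay, with a stated time of 24 h; on this read-out higher numbers stand for weaker inhibition and lower numbers for stronger inhibition:
- compound 1 `CCn1c(C(=O)NCC(=O)OC)ccc1C(CC)(CC)c1ccc(OCS(=O)(=O)c2ccccc2)c(C)c1`: > 50000 nM
- compound 2 `CCn1c(C(=O)N[C@H](C)C(=O)OC)ccc1C(CC)(CC)c1ccc(OCS(=O)(=O)c2ccccc2)c(C)c1`: > 50000 nM

The reading for compound 2, > 50000 nM, is a limit of the assay and not a number. The reading for compound 1, > 50000 nM, is also a limit. So the whole record so far is the limit of > 50000 nM in this assay, at which 2 of the 2 values shown sit, and compound 2 has no exact place on the scale.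

The next compound, compound 3 `CCn1c(C(=O)NCCC(=O)OC)ccc1C(CC)(CC)c1ccc(OCS(=O)(=O)c2ccccc2)c(C)c1`, keeps the shared core and differs only on an amide-type nitrogen: 2-(methoxycarbonyl)ethyl in place of 1-(methoxycarbonyl)ethyl on an amide-type nitrogen. In words, 2-(methoxycarbonyl)ethyl stands in place of 1-(methoxycarbonyl)ethyl, with the same atoms joined differently.

Among the measured compounds shown here, the only measured step offers no size to carry over, as it is a step that the two limits leave unreadable from compound 1 to compound 2. The expectation therefore rests on compound 2 and its limit of > 50000 nM. In this assay, no change beyond the usual scatter and no particular direction is expected, so the estimated step is a step that the limit leaves unreadable from compound 2 to compound 3. The assay may well report only a limit again. For compound 3 the expected value is 60000 nM, with an estimated range from 25000 nM to 150000 nM.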

Compound 3, half-maximal inhibitory concentration: > 50000 nM
Compound 3 ended at the assay's limit; the forecaster's own chance of this, stated with the estimate: 85%; the middle value does not contradict the limit.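

In this assay, compound 3 gives > 50000 nM, which is a limit of the assay and not a number. No step among compound 1, compound 2 and compound 3 can be read, because all three share one limit: the limit of > 50000 nM in this assay, at which 3 of the 3 values shown sit.

The compounds shown leave open whether the group on the amide-type nitrogen affects antiproliferative activity at all, since none of them has an exact place on the scale.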